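The source may report more compounds than this note shows. Statements on the series, on what has been measured and on what is new or still open speak of the compounds shown alone.

Measured so far in an in vivo ADME assay on the whole organism for metabolic stability, with Rattus norvegicus as the target, using cassette dosing; a lower number here means that the compound disappears faster, a higher number that the compound lasts longer:

- compound 1, `CO[C@@H]1C[C@H](C(=O)Nc2ccc(-n3ccccc3=O)cn2)N(C(=O)Nc2ccc(Cl)cc2)C1`: 2 h
- compound 2, `CO[C@]1(C)C[C@H](C(=O)Nc2ccc(-n3ccccc3=O)cc2F)N(C(=O)Nc2ccc(Cl)cc2)C1`: 1.7 h
- compound 3, `Cc1cccc([C@@]2(O)C[C@H](C(=O)Nc3ccc(-n4ccccc4=O)cn3)N(C(=O)Nc3ccc(Cl)cc3)C2)c1`: 1.4 h

The three numbers lie within the usual scatter of one another, so compound 3 cannot be set apart from compound 1 or compound 2 in this assay; its half-life sits in the same band as both. Within the data shown here, no single-point steps between measured compounds are available, and compound 2 and compound 1 differ from compound 3 in more than one place, so none of the pairs gives a clean read on a single change.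

The next compound is compound 4, `O=C(Nc1ccc(-n2ccccc2=O)cn1)[C@H]1C[C@](O)(c2ccccc2Cl)CN1C(=O)Nc1ccc(Cl)cc1`. Relative to compound 3 the change is 2-chlorophenyl in place of 3-methylphenyl on a saturated ring carbon, in words: 2-chlorophenyl in place of 3-methylphenyl on a saturated ring carbon. Nothing in the data speaks to this exchange; the rest of the structure of compound 3 is kept. Among the measured compounds shown here, with no measured step to lean on, the expectation is that the change from compound 3 to compound 4 stays within the scatter, estimated as no change at the digits printed from compound 3 to compound 4 (within the scatter). Compound 4 is therefore expected near 1.4 h, with a range from 0.7 h to 2.8 h in this assay.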

Compound 4, half-life: 2.9 h
Estimate against measurement, compound 4: 2.1-fold (0.32 log units) below; the whole stated range lies below it.
By their numbers in this assay, from the lowest: compounds 3, 2, 1 and 4 (each within the scatter of the next, the first and the last beyond it).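

Among these compounds, at the saturated ring carbon two ring bonds from the ring nitrogen, this is the first change that can be read in one place: in this assay, 2-chlorophenyl in place of 3-methylphenyl gives a 2.1-fold higher number from compound 3 to compound 4 (0.32 log units; beyond the scatter), a modest step. The half-life therefore responds to the choice of aryl group at this position, even though the two groups match in heavy-atom count and in their counts of hydrogen-bond donors and acceptors. Nothing in the data explains the step.

The exchange alters both the substituent and its place on the phenyl ring, so the step cannot be assigned to either without 2-methylphenyl or 3-chlorophenyl at this carbon. Also open, going by these compounds, is how this read-out would respond to a non-aromatic group here, such as an amine or a carboxylic acid.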